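Series notes: from compound 2 toward compound 3

The source may report more compounds than this note shows. Statements on the series, on what has been measured and on what is new or still open speak of the compounds shown alone.

Two compounds of the shared core have numbers in an ADME assay on Vero cells (Chlorocebus sabaeus) for cytotoxicity, read by MTT assay, with a stated time of 72 h; a higher number here means that more compound is tolerated, a lower number that less compound is tolerated. Compound 1 `O=C(/C=C/c1ccco1)Nc1nnc(-c2ccccc2)[nH]1` gives 2180000 nM in this assay. Compound 2 `O=C(/C=C/c1ccc(Cl)cc1)Nc1nnc(-c2ccccc2)[nH]1` gives 1620000 nM in this assay, the lowest of the two numbers, with compound 1 nearest; the step of a 1.3-fold lower number from compound 1 to compound 2 (0.13 log units; within the scatter) is within the scatter, so no order between the two is claimed. Compound 3 `O=C(/C=C/c1ccc([N+](=O)[O-])s1)Nc1nnc(-c2ccccc2)[nH]1` is not yet measured. It differs from compound 2 by 5-nitrothiophen-2-yl in place of 4-chlorophenyl on a double-bonded chain carbon bound to a double-bonded chain carbon. Going by the values given here, no measured step covers this exchange; the only step, a 1.3-fold lower number from compound 1 to compound 2 (0.13 log units; within the scatter), swapped the group at the same place and stayed within the scatter. On that basis the change is expected to stay within the scatter in this assay, with no clear direction, giving the expected step of a 1.2-fold lower number from compound 2 to compound 3 (0.10 log units; within the scatter). Compound 3 is therefore estimated at 1300000 nM in this assay, in the range 400000 nM to 3500000 nM.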

Compound 3, half-maximal cytotoxic concentration: 1670000 nM
Compound 3: middle estimate off by 1.3-fold (0.11 log units), on the low side; low and high end bracket the measured number.
By their numbers in this assay, from the lowest: compounds 2, 3 and 1 (each within the scatter of the next).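

With 5-nitrothiophen-2-yl on a double-bonded chain carbon bound to a double-bonded chain carbon, this assay still separates none of the compounds: the exchange for 4-chlorophenyl gives a 1.0-fold higher number from compound 2 to compound 3 (0.01 log units; within the scatter) and the exchange for furan-2-yl gives a 1.3-fold lower number from compound 1 to compound 3 (0.12 log units; within the scatter) in this series. The flat reading at this place now holds across three groups and extends to one with sulfur in its five-membered aromatic ring and with 3 hydrogen-bond acceptors, where the earlier pair offered a single step. No measurement available here accounts for this flatness.

As far as these compounds go, whether the same holds for a group without an aromatic ring at this place, such as an amine, a carboxylic acid or a longer chain, remains open. From the compounds shown here alone, the effect of any exchange elsewhere on the shared core also remains open, as all three compounds keep it unchanged.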